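The source may hold more compounds than are shown below. What is called first, only, known or untested is meant among the compounds shown, and "the series" means these compounds.

Compound 2 `COc1ccc(-c2cn(-c3cccc(C(=O)/C=C/c4cc(OC)c(OC)c(OC)c4)c3)c(=O)[nH]2)cc1` gives 1780 nM in a functional assay on OVCAR-3 cells (Homo sapiens) for inhibition (a lower number here means a stronger inhibitor of growth, a higher number a weaker inhibitor of growth), the lowest of two numbers, and compound 1 `COc1cc(/C=C/C(=O)c2cccc(-n3cc(-c4ccc(Cl)cc4)[nH]c3=O)c2)cc(OC)c1OC` gives 2400 nM, a gap within the scatter. Going by the values given here, the only measured step, a 1.3-fold lower number from compound 1 to compound 2 (0.13 log units; within the scatter), swaps one group on an aromatic carbon and stays within the scatter. Compound 3 `COc1cc(/C=C/C(=O)c2cccc(-n3cc(-c4cc(OC)c(OC)c(OC)c4)[nH]c3=O)c2)cc(OC)c1OC` carries 3,4,5-trimethoxyphenyl in place of 4-methoxyphenyl on an aromatic carbon. Among the compounds with values here, no measured step tests a change from 4-methoxyphenyl to 3,4,5-trimethoxyphenyl, so in this assay the step expected for compound 3 is a 1.0-fold higher number from compound 2 to compound 3 (0.00 log units; within the scatter), no larger than the scatter. Compound 3 is therefore estimated at 1800 nM, with a range from 700 nM to 4500 nM.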

Compound 3, concentration for 50% growth inhibition: 1480 nM
Compound 3: the middle estimate sits 1.2-fold (0.09 log units) above what was measured; measured number inside the range.
By their numbers in this assay, from the lowest: compounds 3, 2 and 1 (each within the scatter of the next).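

In this assay, the aromatic carbon of the five-membered ring accepts a group of 12 heavy atoms in place of one of 8 with no change beyond the scatter: 3,4,5-trimethoxyphenyl in place of 4-methoxyphenyl gives a 1.2-fold lower number from compound 2 to compound 3 (0.08 log units; within the scatter). Set against 4-chlorophenyl, the same group gives a 1.6-fold lower number from compound 1 to compound 3 (0.21 log units; within the scatter), so all three phenyl groups read alike here. No outside evidence bears on this result.

Still open, as far as these compounds go, is whether a group without a phenyl ring, such as an amine or a carboxylic acid, would keep the number in this range at this position.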